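This account rests on a few compounds, and the source may have more. Where it says the series, first, only, none or still open, it means among the compounds named here.

Compound 1 `COc1ccc(-c2cc(O)c3cccnc3n2)cc1`: 20900 nM
Compound 2 `COc1ccc(-c2cc(O)c3c(C)cc(C)nc3n2)cc1`: 33100 nM

These two compounds are the only ones measured so far in a functional assay on MDA-N cells (Homo sapiens); a higher number here means a weaker inhibitor of growth, a lower number a stronger inhibitor of growth. Compound 2, at 33100 nM, stands within the scatter of compound 1, at 20900 nM, so neither can be ranked above the other. Compound 3 `COc1ccc(-c2cc(O)c3ccc(C)nc3n2)cc1` has not yet been measured. It carries hydrogen in place of methyl on an aromatic carbon, opposite the ring nitrogen (hydrogen in place of methyl on an aromatic carbon). Among the compounds with values here, no measured pair differs in just one place, so this change has no direct precedent. Compound 3 keeps only part of what separates compound 2 from compound 1, and those two values show no gap beyond the scatter. No step beyond the scatter is therefore expected in this assay. The estimated 1.3-fold lower number from compound 2 to compound 3 (0.10 log units; within the scatter) stays within the scatter. For compound 3 the expected value is 26000 nM, with an estimated range of 13000 nM to 50000 nM.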

Compound 3, concentration for 50% growth inhibition: 55000 nM
Estimate against measurement, compound 3: 2.1-fold (0.33 log units) below, and the stated range ends below it.
By their numbers in this assay, from the lowest: compounds 1, 2 and 3 (each within the scatter of the next, the first and the last beyond it).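

In this assay, the exchange of the methyl opposite the ring nitrogen for hydrogen comes to a 1.7-fold higher number from compound 2 to compound 3 (0.22 log units; within the scatter), so this position does not separate methyl from hydrogen here. Within the data shown here, the other methyl, the one compound 3 keeps, gives the first single-place step beyond the scatter, a 2.6-fold higher number from compound 1 to compound 3 (0.42 log units; beyond the scatter), a modest loss of growth inhibition when it is added to the core of compound 1. Nothing measured here explains either step.

Going by these compounds, whether an amine, a chlorine or an ethyl group opposite the ring nitrogen would give a step beyond the scatter remains open. So does whether any of these groups, put in place of the methyl that compound 3 keeps, would give a larger or a smaller step than that methyl does.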